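A few compounds are considered here, and "the series" means these few. Any claim that something is new, unique, unknown or untested is made for them only; others in the source may bear on it.

Measured so far in a functional assay (a lower number here means a stronger inhibitor, a higher number a weaker inhibitor), are three compounds:
- compound 1 `CC(C)=CCOc1cc(O)c2c(c1)OC(c1ccccc1F)CC2=O` at 5300 nM
- compound 2 `CC(C)=CCOc1cc(O)c2c(c1)OC(c1cccc(Cl)c1)CC2=O` at 6060 nM
- compound 3 `CC(C)=CCOc1cc(O)c2c(c1)OC(c1ccc(Cl)cc1Cl)CC2=O` at 3340 nM

These three share one core and differ only in the substituted phenyl group. Compound 3 cannot be told apart from the other two on these numbers. The data show a 1.6-fold lower number from compound 1 to compound 3 (0.20 log units; within the scatter) and also a 1.8-fold lower number from compound 2 to compound 3 (0.26 log units; within the scatter), so neither gap separates it from its neighbours.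

The next compound, compound 4 `CC(C)=CCOc1cc(O)c2c(c1)OC(c1ccc(C)cc1)CC2=O`, brings one structural change: 4-methylphenyl in place of 2,4-dichlorophenyl on a saturated ring carbon. In words, this is 4-methylphenyl in place of 2,4-dichlorophenyl on a saturated ring carbon, next to the ring oxygen.

Among the measured compounds shown here, no measured compound carries 4-methylphenyl, so the evidence is indirect. The best guide is the set of swaps already made at this same place. Besides the two steps above, there is a 1.1-fold higher number from compound 1 to compound 2 (0.06 log units; within the scatter), and thus all three stayed within the scatter. On that basis, no step beyond the scatter is expected in this assay, in either direction.

For compound 4 the expected step is a 1.4-fold higher number from compound 3 to compound 4 (0.16 log units; within the scatter), which would not set it apart. Compound 4 is estimated at 4800 nM, with an expected range from 2400 nM to 9500 nM in this measurement.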

Compound 4, half-maximal inhibitory concentration: 4360 nM
Compound 4: the middle estimate sits 1.1-fold (0.04 log units) above what was measured; low and high end bracket the measured number.
By their numbers in this assay, from the lowest: compounds 3, 4, 1 and 2 (each within the scatter of the next).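

In this assay, among the compounds shown here, 4-methylphenyl is the first group at this saturated ring carbon to carry no halogen at all, since its seven heavy atoms are all carbon, and the swap gives a 1.3-fold higher number from compound 3 to compound 4 (0.12 log units; within the scatter). The comparisons with the two other compounds read the same way, with a 1.4-fold lower number from compound 2 to compound 4 (0.14 log units; within the scatter) and a 1.2-fold lower number from compound 1 to compound 4 (0.08 log units; within the scatter), so replacing fluorine or chlorine with a methyl group produces no step beyond the scatter. Across these four compounds, then, a halogen on the phenyl ring is not required to keep the number in this range, and none of the compounds goes against that, but no other data are available to explain why the position responds so little.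

Going by these compounds, all four groups are phenyl rings bearing only halogen or methyl, with no hydrogen-bond donors or acceptors, so it remains open whether an amine, a carboxylic acid or a hydroxyl on that ring, or a pyridine ring in its place, would move the number beyond the scatter. On these data alone, how far changes elsewhere on the shared core would matter also remains open.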